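Amide aryl swap in a non-cytotoxic pair

The source may report more compounds than this note shows. Statements on the series, on what has been measured and on what is new or still open speak of the compounds shown alone.

Measured compounds:
compound 1 `C=CC1=C(C(=O)Nc2ccccc2OC)C(c2ccc(F)cc2)OC1`: > 100000 nM
compound 2 `C=CC1=C(C(=O)Nc2ccccc2)C(c2ccc(OC)cc2)OC1`: > 100000 nM

In a functional assay on HeLa cells (Homo sapiens) for cytotoxicity, read by MTT assay, with a stated time of 24 h (a lower number here means a stronger inhibitor, a higher number a weaker inhibitor), compound 1 gives > 100000 nM, a limit of the assay rather than a number. Compound 2 gives > 100000 nM, also a limit. Compound 1 therefore stands at the limit of > 100000 nM in this assay, at which 2 of the 2 values shown sit, with no numbered value anywhere in the set. Compound 3 `C=CC1=C(C(=O)Nc2cccc(C)c2)C(c2ccc(F)cc2)OC1` differs from compound 1 by 3-methylphenyl in place of 2-methoxyphenyl on an amide-type nitrogen. Going by the values given here, no step between measured compounds is available to size such a change. The expectation is no step beyond the scatter in this assay, the expected step being a number no higher from compound 1 to compound 3 (the limit leaves the size open). Compound 3 is estimated at 100000 nM (40000 nM to 300000 nM), most likely again reported only as a limit.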

Compound 3, half-maximal inhibitory concentration: "not active" (no number reported)
Compound 3 has no reported number here; no gap can be computed for the estimate.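

No step can be read from compound 1 to compound 3: compound 3 carries no number, and compound 1 stands only at a limit. The compounds shown leave open whether any amide aryl group on the shared core gives a measurable value in this assay.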